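A few compounds are considered here, and "the series" means these few. Any claim that something is new, unique, unknown or untested is made for them only; others in the source may bear on it.

Measured so far:
- compound 1 `CC1=C(C(=O)OC(C(F)(F)F)C(F)(F)F)C(c2ccoc2)NC(=O)N1`: 1%
- compound 2 `CCOC(=O)C1=C(C(F)(F)F)NC(=O)NC1c1cccs1`: 1%
- compound 3 `CC1=C(C(=O)OC(C)C(F)(F)F)C(c2ccoc2)NC(=O)N1`: 12%; 5% (2 entries)

All three values come from an assay on HeLa cells for displacement of a labelled ligand from adenosine receptor A3 (Homo sapiens), read by radioligand binding, with a stated time of 180 min, tested at 1 uM; on this read-out higher numbers stand for more inhibition at the one concentration tested (going by the name of the read-out) and lower numbers for less inhibition. In this assay compound 1 gives 1%, and compound 2 gives 1%, so compound 1 stands level with compound 2 at the digits shown. Compound 3 was measured twice, (the several entries of compound 3 in this assay, 12%; 5% (2 entries)), and the spread between those two repeats gives a feel for how much the same compound can vary from one run to the next. Every value here is small and the three compounds sit close together, so none of them stands apart from the rest.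

The unmeasured compound 4 `CC1=C(C(=O)OC(C(F)(F)F)C(F)(F)F)C(c2ccco2)NC(=O)N1` has the same atoms as compound 1, joined differently: furan-2-yl in place of furan-3-yl on a saturated ring carbon. Within the data shown here, no measured pair of compounds differs in this way, so there is nothing to set the size of the change from. The expected step is a number 2 percentage points higher from compound 1 to compound 4 (within the scatter), which is no more than the usual scatter and in no particular direction. Compound 4 is therefore estimated to give 3%, with a range from 0% to 15%.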

Compound 4, a percentage reported as inhibition, at one concentration (the size of the read-out at that concentration, not a potency): 2%
Beside the measured number, compound 4's estimate is 1 percentage points above it, within the range that was stated.
By their numbers in this assay, from the lowest: compounds 1, 2 and 4 (each within the scatter of the next).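

Among these compounds, this is the first pair here that differs in one place, so the way the furan is attached can be read directly. In this assay, furan-2-yl in place of furan-3-yl on a saturated ring carbon gives a number 1 percentage points higher from compound 1 to compound 4 (within the scatter), so with this core and this ester the read-out does not separate the two furans. Repeat measurements of a single compound can spread further than this step: the several entries of compound 3 in this assay, 12%; 5% (2 entries)

Since both furan compounds give small numbers at the one concentration tested, the pair cannot show how much this position matters in a compound that inhibits more. As far as these compounds go, whether a different group here, such as a phenyl ring or a ring carrying an amine, would give a larger number stays open, as does whether the same furan swap would read alike with the ester of compound 3.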